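Swapping a bromine for a nitro group on a triazole-linked phenyl ring

The compounds below may be only part of what the source reports. "The series", "measured", "known", "first", "only" and "open" are said of these compounds alone.

Of the compounds shown here, two sharing one large terpenoid core have been tested in a functional assay on A549 cells (Homo sapiens) for cytotoxicity, read by MTT assay, with a stated time of 48 h; on this read-out higher numbers stand for weaker inhibition and lower numbers for stronger inhibition. Compound 1 `CC(C)=CCC/C(C)=C/CC/C(C)=C/CC[C@@H]1[C@@]2(C)C/C(=C\c3ccc(OCc4cn(-c5ccc(F)cc5)nn4)cc3)C(=O)C(C)(C)[C@@H]2CC[C@@]1(C)O` carries a 4-fluorophenyl group on the triazole nitrogen; in this assay compound 1 gives 55200 nM. Compound 2 `CC(C)=CCC/C(C)=C/CC/C(C)=C/CC[C@@H]1[C@@]2(C)C/C(=C\c3ccc(OCc4cn(-c5cccc(Br)c5)nn4)cc3)C(=O)C(C)(C)[C@@H]2CC[C@@]1(C)O` carries a 3-bromophenyl group in that position; in this assay compound 2 gives 33800 nM. The step from one to the other, a 1.6-fold lower number from compound 1 to compound 2 (0.21 log units; within the scatter), is too small to rank the two, so compound 2 simply shows the lower of the two numbers, with compound 1 close beside it.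

Compound 3 `CC(C)=CCC/C(C)=C/CC/C(C)=C/CC[C@@H]1[C@@]2(C)C/C(=C\c3ccc(OCc4cn(-c5cccc([N+](=O)[O-])c5)nn4)cc3)C(=O)C(C)(C)[C@@H]2CC[C@@]1(C)O` differs from compound 2 by nitro in place of bromo on an aromatic carbon, the new group sitting on the ring meta to a large group. Among the compounds with values here, no measured pair compares a nitro group with a bromine, so the only guide is the fluorine-to-bromine step between compound 1 and compound 2, which stayed within the scatter. On that basis no step beyond the scatter is expected here, and the expected change from compound 2 to compound 3 is a 1.1-fold higher number from compound 2 to compound 3 (0.03 log units; within the scatter). In this assay compound 3 is therefore estimated at 36000 nM, expected to fall between 15000 nM and 85000 nM.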

Compound 3, half-maximal inhibitory concentration: 126000 nM
Compound 3: the middle estimate sits 3.5-fold (0.54 log units) below what was measured; the whole stated range lies below it.
By their numbers in this assay, from the lowest: compounds 2 and 1 (each within the scatter of the next); then compound 3.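

In this assay, within the data shown here, the group on this ring does matter: putting nitro where bromo stood gives a 3.7-fold higher number from compound 2 to compound 3 (0.57 log units; beyond the scatter) and is the first step in this short series to lie beyond the scatter, in the direction of weaker inhibition. The replacement of 4-fluorophenyl by 3-nitrophenyl points the same way, with a 2.3-fold higher number from compound 1 to compound 3 (0.36 log units; beyond the scatter) so compound 3 stands apart from both halogen-bearing compounds, which could not be told apart from each other. Nothing available explains why the nitro compound behaves differently.

The three compounds cannot show whether this loss is particular to the nitro group or would also follow from other replacements for the bromine, such as an amine, a carboxylic acid or a methoxy group on the same ring carbon. On these data alone, because the step from compound 1 to compound 3 changes both the group and its place on the ring, it also remains open how much of that step comes from the group and how much from its place, and a 3-fluorophenyl or 4-bromophenyl partner would be needed to separate the two.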